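Varying the aryl on the triazole of a sesquiterpene oxime

This account rests on a few compounds, and the source may have more. Where it says the series, first, only, none or still open, it means among the compounds named here.

Measured so far in a functional assay on MCF7 cells (Homo sapiens) for cytotoxicity, read by MTT assay, with a stated time of 48 h; a higher number here means a weaker inhibitor, a lower number a stronger inhibitor:
- compound 1 `CC(C)=CCC/C(C)=C/CC/C(C)=C/CC[C@@H]1[C@@]2(C)CC/C(=N\OCc3cn(-c4cccc(Br)c4)nn3)C(C)(C)[C@@H]2CC[C@@]1(C)O`: 24800 nM
- compound 2 `COc1cc(OC)c(-n2cc(CO/N=C3\CC[C@]4(C)[C@@H](CC/C=C(\C)CC/C=C(\C)CCC=C(C)C)[C@](C)(O)CC[C@H]4C3(C)C)nn2)c(OC)c1`: 14700 nM
- compound 3 `CC(C)=CCC/C(C)=C/CC/C(C)=C/CC[C@@H]1[C@@]2(C)CC/C(=N\OCc3cn(-c4ccncc4)nn3)C(C)(C)[C@@H]2CC[C@@]1(C)O`: 12600 nM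

All three share one core and differ only in the aryl group attached to the aromatic nitrogen. Compound 1 shows the highest of the three numbers, but the step of a 1.7-fold lower number from compound 1 to compound 2 (0.23 log units; within the scatter) and the step of a 2.0-fold lower number from compound 1 to compound 3 (0.29 log units; within the scatter) both fall within the scatter, as does the step of a 1.2-fold lower number from compound 2 to compound 3 (0.07 log units; within the scatter), so on these data the three compounds cannot be told apart.

Compound 4 `CC(C)=CCC/C(C)=C/CC/C(C)=C/CC[C@@H]1[C@@]2(C)CC/C(=N\OCc3cn(-c4ccc(F)c(F)c4F)nn3)C(C)(C)[C@@H]2CC[C@@]1(C)O` takes the same core and changes the aryl group once more: 2,3,4-trifluorophenyl in place of 3-bromophenyl on an aromatic nitrogen. Within the data shown here, the only steps that bear on this change are the two aryl swaps from compound 1 already described, and neither moved the number beyond the scatter. With a third aryl swap at the same place, no step beyond the scatter is expected in this assay either way.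

Compound 4 is therefore expected to give about 20000 nM, with a range from 8000 nM to 50000 nM, which corresponds to an estimated step of a 1.2-fold lower number from compound 1 to compound 4 (0.09 log units; within the scatter).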

Compound 4, half-maximal inhibitory concentration: 32300 nM
For compound 4 the middle estimate is 1.6-fold (0.21 log units) below the measured one; the measured number falls inside the stated range.
By their numbers in this assay, from the lowest: compounds 3, 2, 1 and 4 (each within the scatter of the next, the first and the last beyond it).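

Replacing 3-bromophenyl with 2,3,4-trifluorophenyl gives a 1.3-fold higher number from compound 1 to compound 4 (0.11 log units; within the scatter), so this swap on its own cannot be told apart from no change in this assay. Among these compounds, compound 4 nevertheless provides the first steps at this position that clear the scatter, a 2.6-fold higher number from compound 3 to compound 4 (0.41 log units; beyond the scatter) and a 2.2-fold higher number from compound 2 to compound 4 (0.34 log units; beyond the scatter), which shows that the group on the aromatic nitrogen can shift the number, although only modestly, and compound 1 stays within the scatter of all three other compounds. Nothing available here accounts for why 2,3,4-trifluorophenyl stands apart from pyridin-4-yl and 2,4,6-trimethoxyphenyl.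

From the compounds shown here alone, all four compounds carry a six-membered aromatic ring directly on that nitrogen, so it remains open whether a ring is needed there at all, or whether a benzyl group, a butyl chain, or a phenyl ring bearing an amine or a carboxylic acid would behave differently. Going by these compounds, compound 3 gives 12600 nM, and it also remains open whether any group at this position can bring the number far lower, since the shared core stays the same throughout.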